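Fluoro to trifluoromethyl: from compound 3 to compound 4

The compounds below may be only part of what the source reports. "The series", "measured", "known", "first", "only" and "open" are said of these compounds alone.

Measured in a functional assay on HeLa cells (Homo sapiens) for antiproliferative activity, read by MTT assay, with a stated time of 48 h; a lower number here means a stronger inhibitor, a higher number a weaker inhibitor:
- compound 1 `Fc1ccc2[nH]c(-c3cn(-c4ccccc4)nc3-c3ccccc3)nc2c1`: 3610 nM
- compound 2 `Cc1ccc2[nH]c(-c3cn(-c4ccccc4)nc3-c3ccccc3)nc2c1`: 6560 nM
- compound 3 `Fc1ccc(-c2nn(-c3ccccc3)cc2-c2nc3cc(F)ccc3[nH]2)cc1`: 1570 nM

Compound 3 has the lowest of the three numbers. Its gap to compound 2 is the wider one, and its gap to compound 1 is the narrower one, though still beyond the scatter. The next structure is compound 4 `Fc1ccc(-c2nn(-c3ccccc3)cc2-c2nc3cc(C(F)(F)F)ccc3[nH]2)cc1`, with trifluoromethyl in place of fluoro on an aromatic carbon.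

Two measured steps are available. The closer precedent is methyl in place of fluoro on an aromatic carbon, which replaces the same fluoro and gave a 1.8-fold higher number from compound 1 to compound 2 (0.26 log units; within the scatter). The other is a different change, fluoro in place of hydrogen on an aromatic carbon, which gave the modest 2.3-fold lower number from compound 1 to compound 3 (0.36 log units; beyond the scatter) and says little about this replacement. Among the measured compounds shown here, no measured compound carries trifluoromethyl, so the direction stays open and the evidence rests on a single replacement. In this assay, a small step is therefore expected, most likely none beyond the scatter. The estimate corresponds to a 1.1-fold higher number from compound 3 to compound 4 (0.06 log units; within the scatter) as the expected step. For compound 4 the estimated value is 1800 nM, with an expected range from 700 nM to 4500 nM.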

Compound 4, half-maximal inhibitory concentration: 3520 nM
Compound 4: the middle estimate sits 2.0-fold (0.29 log units) below what was measured; low and high end bracket the measured number.
By their numbers in this assay, from the lowest: compound 3; then compounds 4, 1 and 2 (each within the scatter of the next).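

In this assay, replacing fluoro on this aromatic carbon now gives a step beyond the scatter, a 2.2-fold higher number from compound 3 to compound 4 (0.35 log units; beyond the scatter), so the position is not indifferent to what it carries, and with trifluoromethyl the number moves upward rather than downward. The only earlier replacement of the same fluoro, a 1.8-fold higher number from compound 1 to compound 2 (0.26 log units; within the scatter), stayed within the scatter and was read on a different background, since compound 1 lacks the fluoro that compound 3 carries on its other aromatic ring; the two steps therefore share a direction, but they cannot separate the effect of the entering group from that of the background. Nothing available accounts for the size or direction of the new step.

Still open, on these data alone, is how methyl behaves on the background of compound 3, which would show whether the two replacements truly differ or only appear to. Also open, as far as these compounds go, is whether any group at this carbon, such as an amine, a nitrile or a methoxy group, gives a lower number than fluoro does in compound 3.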